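Triazolylmethylthio pyrimidine carbonitriles: methyl to chloro on the benzyl

This account rests on a few compounds, and the source may have more. Where it says the series, first, only, none or still open, it means among the compounds named here.

Measured so far:
compound 1, `COc1ccc(Nc2nc(SCc3cn(Cc4ccccc4Cl)nn3)nc(-c3ccccc3)c2C#N)cc1`: 3990 nM
compound 2, `Cc1ccc(Cn2cc(CSc3nc(Nc4ccc(C)cc4)c(C#N)c(-c4ccccc4)n3)nn2)cc1`: 8160 nM

In a functional assay on B16-F10 cells (Mus musculus) for inhibition, read by MTT assay, with a stated time of 72 h (a higher number here means a weaker inhibitor, a lower number a stronger inhibitor), compound 2 gives 8160 nM, the higher of the two numbers; compound 1 sits lower, and the gap between them is beyond the scatter. Compound 3, `Cc1ccc(Nc2nc(SCc3cn(Cc4ccccc4Cl)nn3)nc(-c3ccccc3)c2C#N)cc1`, is not yet measured. Relative to compound 2 it carries 2-chlorophenyl in place of 4-methylphenyl on a saturated chain carbon bound to an aromatic nitrogen, so that its benzyl half matches compound 1 while its aryl amine matches compound 2. For the measured compounds named here, no measured step isolates this change. Compound 3 is expected to give a somewhat lower number than compound 2, on the order of the difference that compound 1 shows, and the expected step is a 1.8-fold lower number from compound 2 to compound 3 (0.26 log units; within the scatter). The estimate for compound 3 is 4500 nM, within 2000 nM to 10000 nM.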

Compound 3, half-maximal inhibitory concentration: 3390 nM
Compound 3: middle estimate off by 1.3-fold (0.12 log units), on the high side; measured number inside the range.
By their numbers in this assay, from the lowest: compounds 3 and 1 (each within the scatter of the next); then compound 2.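

In this assay, for the compounds shown here, 2-chlorobenzyl in place of 4-methylbenzyl gives the first reading of this position with only one place changed, a 2.4-fold lower number from compound 2 to compound 3 (0.38 log units; beyond the scatter), so the benzyl half moves the number. With 2-chlorobenzyl held, methyl in place of methoxy on an aromatic carbon gives a 1.2-fold lower number from compound 1 to compound 3 (0.07 log units; within the scatter), so the aryl amine swap does not separate these two compounds. No supporting measurement accompanies either step.

The benzyl step changes both the group and its place, so the two contributions cannot be told apart. From the compounds shown here alone, a plain benzyl as reference remains open, as does a longer chain in its place.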